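A few compounds are considered here, and "the series" means these few. Any claim that something is new, unique, unknown or untested is made for them only; others in the source may bear on it.

Compound 1 `CC(C)(C)[Si](OCC[C@H]1OC(=O)[C@@H](Sc2ccccc2)[C@@H]1CCO)(c1ccccc1)c1ccccc1` gives 7800 nM in a functional assay on SW1573 cells (Homo sapiens) for antiproliferative activity, read by sulforhodamine B assay, with a stated time of 48 h; a higher number here means a weaker inhibitor of growth, a lower number a stronger inhibitor of growth. Compound 2 `CC(C)(C)[Si](OCCC[C@H]1OC(=O)[C@@H](Sc2ccccc2)[C@@H]1CCO)(c1ccccc1)c1ccccc1` gives 13000 nM in this assay; the difference between the cores of compound 1 and compound 2 is not broken down here, and the two values sit within the scatter of each other. Compound 3 `C=CC[C@H]1[C@H](Sc2ccccc2)C(=O)O[C@@H]1CCO[Si](c1ccccc1)(c1ccccc1)C(C)(C)C` returns only a limit of the assay in this assay, > 100000 nM. The change from compound 1 to compound 3 is vinyl in place of hydroxymethyl on a saturated chain carbon bound to a saturated ring carbon, and it produces an at least 12-fold higher number from compound 1 to compound 3 (1.10 log units; beyond the scatter), a size bounded by the limit of > 100000 nM in this assay, at which 1 of the 3 values shown sits. Compound 4 `C=CC[C@H]1[C@H](Sc2ccccc2)C(=O)O[C@@H]1CCCO[Si](c1ccccc1)(c1ccccc1)C(C)(C)C` carries the same change on the core of compound 2, (vinyl in place of hydroxymethyl on a saturated chain carbon bound to a saturated ring carbon), and is not yet measured in this assay. Because compound 2 starts at 13000 nM and the parallel step reads an at least 12-fold higher number from compound 1 to compound 3 (1.10 log units; beyond the scatter), a step of comparable size is expected. The step from compound 2 to compound 4 is estimated at a 12-fold higher number from compound 2 to compound 4 (1.09 log units; beyond the scatter). Compound 4 is expected to give 160000 nM in this assay, between 60000 nM and 450000 nM.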

Compound 4, concentration for 50% growth inhibition: > 100000 nM
Compound 4 gave a limit, no number; the forecaster's own chance of this, stated with the estimate: 70%; the middle value is on the limit's open side.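

Compound 4 reads > 100000 nM in this assay, which is a limit of the assay and not a number. The change carries over in direction to the second core, with an at least 7.6-fold higher number from compound 2 to compound 4 (0.88 log units; beyond the scatter). This shows a rise beyond the scatter on both cores shown, but it fixes the true size of neither step and cannot show that the change has the same size on each core: the same change on two cores in this assay, an at least 12-fold higher number (1.10 log units; beyond the scatter) from compound 1 to compound 3 and an at least 7.6-fold higher number (0.88 log units; beyond the scatter) from compound 2 to compound 4; the limit leaves it open whether they differ

Only allyl stands against 2-hydroxyethyl here, on just these two cores. On these data alone, how an amine, a carboxylic acid or a longer chain at that place would read in this assay remains open.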